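Isopropyl for Methoxyethyl on an Aromatic Nitrogen

The compounds below may be only part of what the source reports. "The series", "measured", "known", "first", "only" and "open" are said of these compounds alone.

Of the compounds shown here, three have been tested in a functional assay on FaDu cells (Homo sapiens) for cytotoxicity, read by MTT assay, with a stated time of 72 h; on this read-out higher numbers stand for lower toxicity in this test and lower numbers for higher toxicity in this test. Among the measured compounds shown here, compound 2 `COCCn1cc(C(=O)C(=O)Nc2ccc(OC(F)(F)F)cc2)c2ccccc21` gives 487 nM, the only plain number among them. Compound 3 `COCCn1cc(C(=O)C(=O)Nc2ccc(OC)nc2)c2cc(OC)ccc21` reaches only a limit of this assay, > 10000 nM. Compound 1 `COc1ccc2c(c1)c(C(=O)C(=O)Nc1ccc(OC)nc1)cn2C(C)C` likewise stops at a limit, > 10000 nM. The change from compound 3 to compound 1 is isopropyl in place of 2-methoxyethyl on an aromatic nitrogen, and its size is a step that the two limits leave unreadable from compound 3 to compound 1 because of the limit of > 10000 nM in this assay, at which 2 of the 3 values shown sit. The difference between the core of compound 2 and the core of compound 3 is not broken down here. Compound 4 `CC(C)n1cc(C(=O)C(=O)Nc2ccc(OC(F)(F)F)cc2)c2ccccc21` carries the same change, (isopropyl in place of 2-methoxyethyl on an aromatic nitrogen), in identical surroundings. With no readable size from the measured pair, the expected step of a 1.2-fold higher number from compound 2 to compound 4 (0.09 log units; within the scatter) rests on compound 2 alone, with its value 487 nM, and is taken as small. Compound 4 is therefore estimated at about 600 nM in this assay.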

Compound 4, concentration lethal to 50% of the cells: 8930 nM
For compound 4 the middle estimate is 15-fold (1.17 log units) below the measured one; the measured number lies above the stated range.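

In this assay, isopropyl in place of 2-methoxyethyl on an aromatic nitrogen gives an 18-fold higher number from compound 2 to compound 4 (1.26 log units; beyond the scatter), so on the core of compound 2 this change clearly goes with lower toxicity. On the core shared by compound 3 and compound 1, the size of the same change cannot be read, because both compounds stop at a limit of the assay: the limit of > 10000 nM in this assay, at which 2 of the 4 values shown sit. Among the compounds shown here, the one readable pair therefore shows a large step on a single core, but it does not show that a step of this size carries over to another core.

On these data alone, it remains open how a chain ending in an amine or a carboxylic acid on that aromatic nitrogen would compare with 2-methoxyethyl and isopropyl. As far as these compounds go, a longer chain there is equally open.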